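Mast cell series: phenyl in place of fluoro

A few compounds are considered here, and "the series" means these few. Any claim that something is new, unique, unknown or untested is made for them only; others in the source may bear on it.

Measured so far:
compound 1 `CC1C/C(=N\Nc2ccccc2)c2ncc(C(=O)O)c(=O)n2C1` — 13000 nM
compound 2 `CC1CC/C(=N\Nc2ccc(F)cc2)c2ncc(C(=O)O)c(=O)n21` — 1200 nM

In a functional assay (mast cells) for inhibition, with Rattus norvegicus as the target (on this read-out higher numbers stand for an effect only at larger amounts of compound and lower numbers for an effect already at smaller amounts), compound 1 gives 13000 nM and compound 2 gives 1200 nM, so compound 2 stands at the lower of the two numbers, and the gap between them lies beyond the scatter. Compound 3 `CC1CC/C(=N\Nc2ccc(-c3ccccc3)cc2)c2ncc(C(=O)O)c(=O)n21` is not yet measured. It differs from compound 2 as follows: phenyl in place of fluoro on an aromatic carbon. For the measured compounds named here, no step between measured compounds covers this change, so the expected size rests on the structures alone; a moderate shift in this assay is expected, in either direction, and a 1.7-fold higher number from compound 2 to compound 3 (0.22 log units; within the scatter) is the estimated step. Compound 3 is expected at 2000 nM, within 400 nM to 10000 nM.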

Compound 3, half-maximal effective concentration: 4400 nM
The estimate for compound 3 lay 2.2-fold (0.34 log units) below the measured number; the range from low to high includes it.
By their numbers in this assay, from the lowest: compound 2; then compound 3; then compound 1.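

In this assay phenyl in place of fluoro on this aromatic carbon gives a 3.7-fold higher number from compound 2 to compound 3 (0.56 log units; beyond the scatter) and so costs activity, a first sign that this position responds to the group it carries. The loss stays modest for an exchange of one heavy atom for six, so a large aromatic ring is accepted here without activity being lost altogether. No measured evidence bears on the origin of this step. Open, from the compounds shown here alone, is where a methoxy group or an amine on the same carbon would fall relative to fluoro and phenyl.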